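Iodinated hydroxy-methoxyphenyl hydrazone in the benzothiazole series

The compounds below may be only part of what the source reports. "The series", "measured", "known", "first", "only" and "open" are said of these compounds alone.

Compound 1 `COc1ccc(/C=N/NC(=O)c2ccc(-c3nc4ccccc4s3)cc2)c(O)c1` holds the lowest number of the two reported in an assay on isolated protein for inhibition of Maltase-glucoamylase (Homo sapiens), with a stated time of 15 min (on this read-out lower numbers stand for stronger inhibition and higher numbers for weaker inhibition), giving 6970 nM. Within the data shown here, compound 2 `COc1cc(/C=N/NC(=O)c2ccc(-c3nc4ccccc4s3)cc2)cc(OC)c1` gives 16200 nM in this assay, and the step of a 2.3-fold higher number from compound 1 to compound 2 (0.37 log units; beyond the scatter) is the only measured change on the ring attached to the carbon with a double bond to nitrogen. Compound 3 `O=C(N/N=C/c1ccncc1)c1ccc(-c2nc3ccccc3s2)cc1` is reported as "not active" (no number reported) in this assay, without a number. Compound 4 `COc1ccc(/C=N/NC(=O)c2ccc(-c3nc4ccccc4s3)cc2)c(I)c1O` carries the change (3-hydroxy-2-iodo-4-methoxyphenyl in place of 2-hydroxy-4-methoxyphenyl on a carbon with a double bond to nitrogen). Among the measured compounds shown here, only the step from compound 1 to compound 2 bears on it, and it was modest; no measured step adds an iodine. Compound 4 is therefore expected to sit close to compound 1, with a step of a 1.0-fold higher number from compound 1 to compound 4 (0.00 log units; within the scatter) and an estimate of 7000 nM within 2500 nM to 20000 nM.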

Compound 4, half-maximal inhibitory concentration: 44800 nM
Compound 4: middle estimate off by 6.4-fold (0.81 log units), on the low side; the whole stated range lies below it.
By their numbers in this assay, from the lowest: compound 1; then compound 2; then compound 4.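

Iodine enters this ring together with a move of the hydroxy group, and 3-hydroxy-2-iodo-4-methoxyphenyl costs more than the earlier change did, with a 6.4-fold higher number from compound 1 to compound 4 (0.81 log units; beyond the scatter) and a 2.8-fold higher number from compound 2 to compound 4 (0.44 log units; beyond the scatter) on the ring at the carbon with a double bond to nitrogen. Among the numbered compounds, compound 4 now marks the high end, so this position does not accept every substituted phenyl equally. The data at hand give no explanation for the loss.

The share of the iodine and the share of the moved hydroxy group remain unseparated. As far as these compounds go, how an amine or a carboxylic acid on this ring would read out also stays open.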